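This account rests on a few compounds, and the source may have more. Where it says the series, first, only, none or still open, it means among the compounds named here.

Measured so far in a physicochemical assay for lipophilicity; on this read-out higher numbers stand for higher lipophilicity and lower numbers for lower lipophilicity:
- compound 1, `CCNC(=O)/C=C(C)/C=C/CC(C)CCCC(C)(C)OC`: 4.04
- compound 2, `CCC(=O)/C=C(C)/C=C/CC(C)CCCC(C)(C)OC`: 5.07
- compound 3, `CCNC(=O)/C=C(C)/C=C/CC(C)CCCC(C)(C)O`: 3.15

Compound 1 and compound 2 differ in one place: ethyl in place of ethylamino on a carbonyl carbon. In this assay that change gave a number 1.03 log units higher from compound 1 to compound 2 (beyond the scatter). Compound 1 and compound 3 differ in another place: hydrogen in place of methyl on an oxygen on a saturated carbon. That change gave a number 0.89 log units lower from compound 1 to compound 3 (beyond the scatter), and compound 3 therefore stands lowest of the three numbers. No single change joins compound 2 to compound 3; their two values alone show compound 2 well above compound 3 in this assay.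

Compound 4, `CCC(=O)/C=C(C)/C=C/CC(C)CCCC(C)(C)O`, has not yet been measured. It differs from compound 3 as follows: ethyl in place of ethylamino on a carbonyl carbon. The place of this change reads word for word the same as the place of the change from compound 1 to compound 2, so it is the same change, made on the core of compound 3 rather than on the core of compound 1; the difference between the two cores is the one already described above between compound 1 and compound 3.

Only one earlier instance of this change exists among the compounds shown, so the expectation rests on a single step. The step from compound 3 to compound 4 in this assay is expected to be about a number 1.03 log units higher from compound 3 to compound 4 (beyond the scatter), close to the earlier step, because the same change gave a number 1.03 log units higher from compound 1 to compound 2 (beyond the scatter). Compound 4 is accordingly expected to give about 4.18 in this assay, within a range of 3.8 to 4.6.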

Compound 4, partition coefficient: 4.18
Beside the measured number, compound 4's estimate shows no gap at the digits printed; measured number inside the range.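

In this assay the change of ethylamino to ethyl on a carbonyl carbon carried from one core to the other with the same size, giving a number 1.03 log units higher from compound 1 to compound 2 (beyond the scatter) and a number 1.03 log units higher from compound 3 to compound 4 (beyond the scatter) on the two cores. The second change in the set behaves alike, since hydrogen in place of methyl on an oxygen on a saturated carbon gave a number 0.89 log units lower from compound 1 to compound 3 (beyond the scatter) and also a number 0.89 log units lower from compound 2 to compound 4 (beyond the scatter), so across these four compounds the two changes add without any visible dependence on each other. This shows transfer between two closely related cores only, resting on one pair for each core and one read-out, so it sets no rule for other cores, and no accompanying measurement accounts for the size of either step.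

From the compounds shown here alone, whether the same step would hold with a longer chain on the carbonyl carbon, such as propyl against propylamino, or with a dimethylamino group in place of ethylamino, remains open. Also open, going by these compounds, is whether the two changes would still add if a carboxylic acid or an amine stood in place of the oxygen group on the saturated carbon.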